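The source may hold more compounds than are shown below. What is called first, only, known or untested is meant among the compounds shown, and "the series" means these compounds.

Values in a functional assay on HCC827 cells (Homo sapiens) for antiproliferative activity, read by MTT assay, with a stated time of 72 h; a lower number here means a stronger inhibitor, a higher number a weaker inhibitor:
Compound 1 `CN1CCN(c2ccc(Nc3ncc4nc([S+]([O-])c5ccccc5)n(CC5CC5)c4n3)cc2)CC1`: 838 nM
Compound 2 `CN1CCN(c2ccc(Nc3ncc4nc(Sc5ccccc5)n(CC5CC5)c4n3)cc2)CC1`: 660 nM
Compound 3 `CN1CCC(Oc2ccc(Nc3ncc4nc(Sc5ccccc5)n(C5CCOCC5)c4n3)cc2)CC1`: 140 nM

Two compounds stand level at the upper end of these numbers, with a 1.3-fold lower number from compound 1 to compound 2 (0.10 log units; within the scatter). Against compound 1, compound 3 gives a lower number, 140 nM.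

The next analogue, compound 4 `CN1CCN(c2ccc(Nc3ncc4nc([S+]([O-])c5ccccc5)n(C5CC5)c4n3)cc2)CC1`, keeps the rest of compound 1 and carries cyclopropyl in place of cyclopropylmethyl on an aromatic nitrogen. Going by the values given here, no measured step isolates this change. Among the compounds with values here, the only single-place step, a 1.3-fold lower number from compound 1 to compound 2 (0.10 log units; within the scatter), concerns a group on an aromatic carbon, so it bears only indirectly. Compound 3 differs from compound 1 in more than one place, so its value cannot be tied to the group on that nitrogen. With so little evidence, no shift beyond the scatter is expected in this assay, in either direction. The expected change is small, an estimated 1.1-fold lower number from compound 1 to compound 4 (0.05 log units; within the scatter). For compound 4 the estimated value is 750 nM, within an expected range of 280 nM to 2000 nM.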

Compound 4, half-maximal inhibitory concentration: 1630 nM
For compound 4 the middle estimate is 2.2-fold (0.34 log units) below the measured one; the measured number falls inside the stated range.
By their numbers in this assay, from the lowest: compound 3; then compounds 2, 1 and 4 (each within the scatter of the next, the first and the last beyond it).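

In this assay the aromatic nitrogen now has a single-place step of its own, and cyclopropyl in place of cyclopropylmethyl gives a 1.9-fold higher number from compound 1 to compound 4 (0.29 log units; within the scatter) and so stays within the usual scatter. With the rest of compound 1 held fixed, this assay therefore does not separate the two groups, although both carry a three-membered carbon ring and differ only by the one carbon counted between them. Nothing measured here offers a reason for this result.

The compounds shown leave open how a group of another kind on this nitrogen would read, such as a longer chain like n-butyl or a chain ending in an amine like 2-aminoethyl. They also leave open whether the same exchange would read alike with the phenylthio group of compound 2 on the aromatic carbon.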